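Hydroxy to carbamoylmethyl on the amino-acid side chain

The source may hold more compounds than are shown below. What is called first, only, known or untested is meant among the compounds shown, and "the series" means these compounds.

Measured compounds:
Compound 1 `N=C(N)NCCC[C@H](NC(=O)CN(c1ncnc2c1ncn2C1CCCCO1)C1CC1)C(=O)OCc1ccccc1` gives 52.4% in a functional assay on the whole organism (Tail, strain ICR) with Mus musculus as the target, in the tail flick test, with a stated time of 60 min, at a dose of 25 umol/kg by the oral route; a higher number here means a stronger effect of the compound at the dose given, a lower number a weaker effect.
Compound 2 `O=C(CN(c1ncnc2c1ncn2C1CCCCO1)C1CC1)N[C@@H](CO)C(=O)OCc1ccccc1` gives 46.7%.
Compound 3 `NCCCC[C@H](NC(=O)CN(c1nc(Cl)nc2[nH]cnc12)C1CC1)C(=O)OCc1ccccc1` gives 41.2%.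

All three values lie within the usual scatter of one another, so compound 2 sits neither clearly above nor below its neighbours. Compound 4 `NC(=O)CC[C@H](NC(=O)CN(c1ncnc2c1ncn2C1CCCCO1)C1CC1)C(=O)OCc1ccccc1` differs from compound 2 by carbamoylmethyl in place of hydroxy on a saturated chain carbon, two bonds along the chain from an amide-type nitrogen and a carbonyl carbon. Among the compounds with values here, the one measured step at this same place, a number 5.7 percentage points lower from compound 1 to compound 2 (within the scatter), stayed within the scatter, and no other measured step bears on this change. Compound 4 is therefore expected to show a step of a number 2.3 percentage points higher from compound 2 to compound 4 (within the scatter), that is, no shift beyond the scatter. Compound 4 is estimated to give 49%, with a range from 35% to 63%.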

Compound 4, a percentage reported as activity, at one dose (the size of the read-out at that dose, not a potency): 39.4%
Estimate against measurement, compound 4: 9.6 percentage points above; the measured number falls inside the stated range.
By their numbers in this assay, from the lowest: compounds 4, 3, 2 and 1 (each within the scatter of the next, the first and the last beyond it).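

In this assay carbamoylmethyl in place of hydroxy on this side chain gives a number 7.3 percentage points lower from compound 2 to compound 4 (within the scatter) and so cannot be told apart from repeat-measurement noise. The same position does now show its first step beyond the scatter, with a number 13 percentage points lower from compound 1 to compound 4 (beyond the scatter) as one side-chain group replaces the other. Nothing available explains that difference. Still open, going by these compounds, is how a carboxylic acid on this side chain, on the same core, would compare with compound 1 and compound 4.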